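Bromo for carboxy on the benzyl ring of compound 3

This account rests on a few compounds, and the source may have more. Where it says the series, first, only, none or still open, it means among the compounds named here.

Measured compounds:
compound 1 `COc1cc(CNc2cc(Br)cc3[nH]ncc23)c([N+](=O)[O-])cc1OC`: 79%
compound 2 `O=C(O)CNc1cccc(CNc2cc(C(F)(F)F)cc3[nH]ncc23)c1`: 8%
compound 3 `O=C(O)c1cccc(CNc2cc(C(F)(F)F)cc3[nH]ncc23)c1`: 17%

In an assay for inhibition of Indoleamine 2,3-dioxygenase 1 (Homo sapiens), with stated times of 10 min and 60 min, tested at 100 uM (on this read-out lower numbers stand for a weaker effect and higher numbers for a stronger effect at the one concentration tested), compound 3 gives 17%, the second highest of the three numbers. Among the compounds with values here, its nearest neighbour is compound 2, and the one step that joins them, a number 9 percentage points higher from compound 2 to compound 3 (within the scatter), lies within the scatter. Within the data shown here, compound 1 stands far above both, yet it differs from compound 3 in more than one place, so no single step is drawn between them.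

Compound 4 `FC(F)(F)c1cc(NCc2cccc(Br)c2)c2cn[nH]c2c1` has not been measured. It differs from compound 3 by bromo in place of carboxy on an aromatic carbon. Among the measured compounds shown here, the only measured step, from compound 2 to compound 3, changes the same aromatic carbon but exchanges one group for another and was within the scatter, so it gives no direct guide to the present change. Compound 1, which carries no carboxy, gives 79%, but its other differences keep this from being a clean comparison.

Compound 4 is therefore estimated to show a number 18 percentage points higher from compound 3 to compound 4 (beyond the scatter), with wide uncertainty. The expected value for compound 4 is 35%, in a range from 10% to 65%.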

Compound 4, a percentage reported as inhibition, at one concentration (the size of the read-out at that concentration, not a potency): 51%
Beside the measured number, compound 4's estimate is 16 percentage points below it, and the stated range covers the measured number.
By their numbers in this assay, from the lowest: compounds 2 and 3 (each within the scatter of the next); then compound 4; then compound 1.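

Within the data shown here, at this aromatic carbon, the earlier pair offered only two carboxy-bearing groups, and a number 9 percentage points higher from compound 2 to compound 3 (within the scatter) in this assay did not separate them, so it remained unclear whether the read-out responded to the group here at all. The bromo compound settles that: bromo in place of carboxy gives a number 34 percentage points higher from compound 3 to compound 4 (beyond the scatter), and bromo in place of (carboxymethyl)amino gives a number 43 percentage points higher from compound 2 to compound 4 (beyond the scatter), so a change at this one position, with the shared core and the trifluoromethyl group kept, is enough to move the number beyond the scatter. Nothing available here ties this rise to any particular feature of bromo or of the groups it replaces.

The three compounds that share this core leave open whether the rise follows from the presence of bromo or simply from the loss of the carboxy, a question that a plain hydrogen, chloro or a nitrile at the same carbon would address. On these data alone, it is also open how an amine or an ester would fare there, and, as every number comes from a single concentration, what potency compound 4 has.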